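The source may report more compounds than this note shows. Statements on the series, on what has been measured and on what is new or still open speak of the compounds shown alone.

Measured so far:
compound 1 `COc1cccc(C(C)Sc2nc3c(cnn3C)c(=O)n2-c2ccccc2)c1` — 451 nM
compound 2 `CC(Sc1nc2nn(C3COC3)cc2c(=O)n1-c1ccccc1)c1ccccn1` — 68 nM

In an assay on isolated protein for inhibition of aldehyde dehydrogenase 1A1 (Homo sapiens) (a lower number here means a stronger inhibitor, a higher number a weaker inhibitor), compound 1 gives 451 nM, the higher of the two numbers; compound 2, which differs from it in several places at once, gives 68 nM. Compound 3 `COc1ccccc1C(C)Sc1nc2c(cnn2C)c(=O)n1-c1ccccc1` keeps the core of compound 1 and differs only by 2-methoxyphenyl in place of 3-methoxyphenyl on a saturated chain carbon bound to a saturated chain carbon and a sulfur. Among the compounds with values here, no measured pair isolates this change, so its direction is not established; a step of modest size, possibly within the scatter, is expected from compound 1 to compound 3, namely a 1.3-fold higher number from compound 1 to compound 3 (0.12 log units; within the scatter). Compound 3 is therefore estimated at 600 nM, in the range 200 nM to 2000 nM.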

Compound 3, half-maximal inhibitory concentration: 445 nM
Estimate against measurement, compound 3: 1.3-fold (0.13 log units) above; low and high end bracket the measured number.
By their numbers in this assay, from the lowest: compound 2; then compounds 3 and 1 (each within the scatter of the next).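

In this assay, within the data shown here, 2-methoxyphenyl in place of 3-methoxyphenyl on a saturated chain carbon bound to a saturated chain carbon and a sulfur gives a 1.0-fold lower number from compound 1 to compound 3 (0.01 log units; within the scatter), the first step that isolates one place. On the core of compound 1, this read-out does not separate these two methoxyphenyl groups. No supporting data bear on this result.

The compounds shown leave open whether 4-methoxyphenyl, unsubstituted phenyl or a carboxylic acid-bearing phenyl in the same place would give a step beyond the scatter.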